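Cyclohexyl in place of ethyl on the ring nitrogen

The source may report more compounds than this note shows. Statements on the series, on what has been measured and on what is new or still open speak of the compounds shown alone.

Compound 1 `Cc1ccc(Nc2ncc3c(n2)N(C2CC2)C(=O)N(c2cc(NC(=O)c4ccc(C)c(C(F)(F)F)c4)ccc2C)C3)cn1`: 649 nM
Compound 2 `Cc1ccc(Nc2ncc3c(n2)N(c2ccccc2)C(=O)N(c2cc(NC(=O)c4ccc(C)c(C(F)(F)F)c4)ccc2C)C3)cn1`: 3300 nM
Compound 3 `CCN1C(=O)N(c2cc(NC(=O)c3ccc(C)c(C(F)(F)F)c3)ccc2C)Cc2cnc(Nc3ccc(C)nc3)nc21`: 708 nM

These three compounds share one core and differ only in the group on an amide-type nitrogen in a ring. The numbers come from an ADME assay on BaF3 cells (Mus musculus) for inhibition, read by CellTiter-Glo, with a stated time of 72 h (a higher number here means a weaker inhibitor of growth, a lower number a stronger inhibitor of growth), and place compound 3 level with compound 1 (a 1.1-fold higher number from compound 1 to compound 3 (0.04 log units; within the scatter)). Compound 2 stands clearly apart from compound 3 (a 4.7-fold lower number from compound 2 to compound 3 (0.67 log units; beyond the scatter)).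

The next compound is compound 4 `Cc1ccc(Nc2ncc3c(n2)N(C2CCCCC2)C(=O)N(c2cc(NC(=O)c4ccc(C)c(C(F)(F)F)c4)ccc2C)C3)cn1`, and the change to it is cyclohexyl in place of ethyl on an amide-type nitrogen in a ring.

Two kinds of step bear on this. Swapping between the two small groups did not move the number (a 1.1-fold higher number from compound 1 to compound 3 (0.04 log units; within the scatter)), and compound 1 shows that carrying a small ring there need not raise it. Of the measured groups, phenyl comes nearest to cyclohexyl in size, and it gave a modest rise (a 5.1-fold higher number from compound 1 to compound 2 (0.71 log units; beyond the scatter)). No large non-aromatic ring has been measured at this place, so the comparison is loose. A modest rise is expected, probably no larger than the phenyl step. The expected step is a 2.1-fold higher number from compound 3 to compound 4 (0.33 log units; beyond the scatter) (an estimate). Compound 4 is estimated at 1500 nM (expected range 550 nM to 4500 nM).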

Compound 4, concentration for 50% growth inhibition: > 5000 nM
Compound 4 ended at the assay's limit (the forecaster's own chance of this, stated with the estimate: 5%); middle value at least 3.3-fold (0.52 log units) away from the limit.
By their numbers in this assay, from the lowest: compounds 1 and 3 (each within the scatter of the next); then compound 2. At a limit, above all of these: compound 4.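

In this assay compound 4 gives > 5000 nM, which is a limit of the assay and not a number: the limit of > 5000 nM in this assay, at which 1 of the 4 values shown sits. Among the non-aromatic groups, this position does not treat all alike: ethyl and cyclopropyl read level, yet the cyclohexyl group gives an at least 7.0-fold higher number from compound 3 to compound 4 (0.84 log units; beyond the scatter) and an at least 7.7-fold higher number from compound 1 to compound 4 (0.88 log units; beyond the scatter), so the rise seen earlier with phenyl is not confined to an aromatic ring. Against phenyl itself the result is less firm, with an at least 1.5-fold higher number from compound 2 to compound 4 (0.18 log units; that floor lies within the scatter), so these two large ring groups cannot be placed in order.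

What the compounds shown leave open is where, between ethyl and cyclohexyl, the number starts to climb, and a cyclopentyl ring or a longer chain such as butyl would bear on that. Going by these compounds, it is also open whether a six-membered ring carrying an amine or a hydroxyl group at this nitrogen would behave as cyclohexyl does, and how far beyond the limit compound 4 truly lies.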